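Swapping a Hydroxy for Pentylsulfanyl on a Shared Core

The compounds below may be only part of what the source reports. "The series", "measured", "known", "first", "only" and "open" are said of these compounds alone.

Of the compounds shown here, three built on the same core have been tested in a functional assay (spleen, spleen) for activation, with Mus musculus as the target; on this read-out higher numbers stand for an effect only at larger amounts of compound and lower numbers for an effect already at smaller amounts. Compound 1 `Nc1nc(O)nc2c1nc(O)n2Cc1ccccc1` gives 0.1 uM. Compound 2 `Nc1nc(SCc2ccccc2)nc2c1nc(O)n2Cc1ccccc1` gives 0.1 uM, and compound 3 `CCOc1nc(N)c2nc(O)n(Cc3ccccc3)c2n1` gives 0.1 uM. On these numbers compound 1 stands level with compound 2 and compound 3: the steps of no change at the digits printed from compound 1 to compound 2 (within the scatter) and no change at the digits printed from compound 1 to compound 3 (within the scatter) both stay within the scatter, as does no change at the digits printed from compound 2 to compound 3 (within the scatter).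

Compound 4 `CCCCCSc1nc(N)c2nc(O)n(Cc3ccccc3)c2n1` has not yet been measured. It differs from compound 1 in one place: pentylsulfanyl in place of hydroxy on an aromatic carbon. The most relevant precedents are the replacement of the same hydroxy by benzylsulfanyl, no change at the digits printed from compound 1 to compound 2 (within the scatter), and of its hydrogen by ethyl, no change at the digits printed from compound 1 to compound 3 (within the scatter), neither of which moved the read-out beyond the scatter. A pentylsulfanyl group at the same aromatic carbon is therefore expected to behave alike, with a step of no change at the digits printed from compound 1 to compound 4 (within the scatter) that amounts to no change. For compound 4 the estimated value in this assay is 0.1 uM, within a range from 0.03 uM to 0.3 uM.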

Compound 4, minimum effective concentration: 10 uM
Compound 4: the middle estimate sits 100-fold (2.00 log units) below what was measured; measured number above the stated range.
By their numbers in this assay, from the lowest: compounds 1, 2 and 3 (each within the scatter of the next); then compound 4.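

This position on the shared core does not accept every group equally: in this assay pentylsulfanyl in place of hydroxy gives a 100-fold higher number from compound 1 to compound 4 (2.00 log units; beyond the scatter) and pentylsulfanyl in place of ethoxy gives a 100-fold higher number from compound 3 to compound 4 (2.00 log units; beyond the scatter) on the same read-out. The sharpest comparison keeps the sulfur and changes only what hangs from it, with butyl in place of phenyl giving a 100-fold higher number from compound 2 to compound 4 (2.00 log units; beyond the scatter) in this series. A sulfur at this aromatic carbon is therefore compatible with the low number of compound 2, and the outcome depends on the rest of the group, although nothing given here explains the difference.

Open, from the compounds shown here alone, is whether a shorter chain such as propylsulfanyl would stay level with compounds 1, 2 and 3 or follow compound 4. Pentyloxy would show whether the same five-carbon chain behaves differently on oxygen, and an amine at this carbon remains another open case.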